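Pyridin-3-yl in place of pyridin-2-yl: an expected step

The source may report more compounds than this note shows. Statements on the series, on what has been measured and on what is new or still open speak of the compounds shown alone.

- compound 1 `COc1cc(C(=O)O)ccc1NC(=O)[C@@H]1N[C@@H](CC(C)(C)C)[C@](CNCc2ccncc2)(c2ccc(Cl)cc2F)[C@H]1c1cccc(Cl)c1F`: 370 nM
- compound 2 `COc1cc(C(=O)O)ccc1NC(=O)[C@@H]1N[C@@H](CC(C)(C)C)[C@](CNCc2ccccn2)(c2ccc(Cl)cc2F)[C@H]1c1cccc(Cl)c1F`: 820 nM

Both values come from a functional assay on U2OS cells (Homo sapiens) for inhibition, read by CCK-8 assay, with a stated time of 4 days; on this read-out lower numbers stand for stronger inhibition and higher numbers for weaker inhibition. Of the two numbers, compound 2 holds the higher one, at 820 nM, so it is the weaker inhibitor of this pair. The next compound, compound 3 `COc1cc(C(=O)O)ccc1NC(=O)[C@@H]1N[C@@H](CC(C)(C)C)[C@](CNCc2cccnc2)(c2ccc(Cl)cc2F)[C@H]1c1cccc(Cl)c1F`, keeps the shared core and differs from compound 2 in one place: pyridin-3-yl in place of pyridin-2-yl on a saturated chain carbon bound to an amine nitrogen. The two have the same atoms, joined differently.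

Among the compounds with values here, only one measured step bears on this change: a 2.2-fold higher number from compound 1 to compound 2 (0.35 log units; beyond the scatter). That modest step, just beyond the scatter, came from pyridin-2-yl in place of pyridin-4-yl at the same place. Within the data shown here, it shows that such a swap can move the number, but pyridin-3-yl itself has no measurement yet. With compound 1 at 370 nM on the lower side, a value for the new isomer near the middle of the pair seems the most reasonable expectation. The estimated change is a 1.5-fold lower number from compound 2 to compound 3 (0.17 log units; within the scatter), a small move toward a lower number in this assay, not one clearly beyond the scatter. For compound 3 the expected value is 550 nM, with an estimated range from 250 nM to 1100 nM.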

Compound 3, half-maximal inhibitory concentration: 860 nM
For compound 3 the middle estimate is 1.6-fold (0.19 log units) below the measured one; measured number inside the range.
By their numbers in this assay, from the lowest: compound 1; then compounds 2 and 3 (each within the scatter of the next).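

Swapping pyridin-2-yl for pyridin-3-yl gives a 1.0-fold higher number from compound 2 to compound 3 (0.02 log units; within the scatter), so in this assay these two isomers cannot be told apart, something the earlier pair could not show. Within the data shown here, this leaves pyridin-4-yl as the one group of the three that stands apart: the swap to pyridin-3-yl gives a 2.3-fold higher number from compound 1 to compound 3 (0.37 log units; beyond the scatter), and the swap to pyridin-2-yl gave a 2.2-fold higher number from compound 1 to compound 2 (0.35 log units; beyond the scatter), so both steps away from compound 1 lie beyond the scatter, though both are modest. The numbers record this difference between the isomers, but nothing shown here accounts for it.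

On these data alone, what remains open is how much the ring nitrogen contributes at this position, which a plain phenyl group in place of the pyridine ring would help to test. As far as these compounds go, it is also open whether the advantage of compound 1 would survive a small change in the link to the ring, such as (pyridin-4-yl)ethyl in place of (pyridin-4-yl)methyl, or an added methyl group on the pyridin-4-yl ring.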